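The source may report more compounds than this note shows. Statements on the series, on what has been measured and on what is new or still open speak of the compounds shown alone.

Working notes on the series. Compound 1 `NC1=NC2(CCOCC2)N(OCCCOc2ccc(Cl)cc2Cl)C(N)=N1` is recorded as "not determined" (no result reported) in an assay on isolated protein for inhibition of Dihydrofolate reductase (Homo sapiens), read by spectrophotometry, using NADPH, with stated times of 5 s and 6 min, tested at 50 uM (a higher number here means a stronger effect of the compound at the concentration tested, a lower number a weaker effect), with no number behind it. Going by the values given here, compound 2 `NC1=NC2(CCOCC2)N(OCCCOc2ccccc2Br)C(N)=N1` gives 85% in this assay, the only number in hand for this series, so nothing stands beside it for comparison. Compound 3 `NC1=NC2(CCOCC2)N(OCCCOc2cccc(Br)c2)C(N)=N1` differs from compound 2 in one place: 3-bromophenyl in place of 2-bromophenyl on an oxygen on a saturated carbon. Among the compounds with values here, no measured step of this kind exists here, so the expected step of a number 10 percentage points lower from compound 2 to compound 3 (within the scatter) from compound 2 to compound 3 in this assay is set small, within the scatter of repeated measurements. For compound 3 the estimate in this assay is 75%, with a range from 50% to 95%.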

Compound 3, a percentage reported as inhibition, at one concentration (the size of the read-out at that concentration, not a potency): 85.8%
Beside the measured number, compound 3's estimate is 10.8 percentage points below it, within the range that was stated.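

Going by these compounds alone, the exchange of 2-bromophenyl for 3-bromophenyl on an oxygen on a saturated carbon gives a number 0.8 percentage points higher from compound 2 to compound 3 (within the scatter) in this assay, the first measured step. At the single concentration tested, this assay therefore does not separate the 2-bromophenoxy and 3-bromophenoxy compounds. Nothing available gives a reason for this result.

As far as these compounds go, whether the same holds with an amine or a carboxylic acid in place of the bromine, or with a longer chain, stays open. A read-out at one concentration also leaves any difference in potency between compound 2 and compound 3 unresolved.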